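Para-methyl swap on imidazopyridine aryl: expected effect on compound 4

A few compounds are considered here, and "the series" means these few. Any claim that something is new, unique, unknown or untested is made for them only; others in the source may bear on it.

Measured compounds:
compound 1 `CC#CC(CC(=O)O)c1ccc(OCc2ccn3cc(-c4ccc(C)cc4)nc3c2)cc1`: 618 nM
compound 2 `CC#CC(CC(=O)O)c1ccc(OCc2ccn3cc(-c4cccc(C)c4)nc3c2)cc1`: 1510 nM
compound 3 `CC#CC(CC(=O)O)c1ccc(OCc2ccc3nc(-c4cccc(C)c4)cn3c2)cc1`: 1050 nM

In an assay on isolated protein for agonist activity at Free fatty acid receptor 1 (Homo sapiens) (a lower number here means that less compound is needed, a higher number that more compound is needed for the effect), compound 2 gives 1510 nM, and compound 1 gives 618 nM. The two share everything except the aryl group on the bicyclic core, and the change 4-methylphenyl in place of 3-methylphenyl on an aromatic carbon produces a 2.4-fold lower number from compound 2 to compound 1 (0.39 log units; beyond the scatter).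

Compound 3 carries the same 3-methylphenyl group as compound 2 but on a core that is joined differently; the difference between the two cores is not broken down here. In this assay compound 3 gives 1050 nM, a value that lies within the scatter of both compound 2 and compound 1, so no order among these three can be claimed.

Compound 4 `CC#CC(CC(=O)O)c1ccc(OCc2ccc3nc(-c4ccc(C)cc4)cn3c2)cc1` has not yet been measured. It is made from compound 3 by 4-methylphenyl in place of 3-methylphenyl on an aromatic carbon, the same change as from compound 2 to compound 1, at a place described in identical words. On that single precedent, compound 4 is expected to show a 2.3-fold lower number from compound 3 to compound 4 (0.37 log units; beyond the scatter) relative to compound 3, because the earlier change gave a 2.4-fold lower number from compound 2 to compound 1 (0.39 log units; beyond the scatter). The estimate for compound 4 in this assay is 450 nM, with a range of 200 nM to 1100 nM, resting only on one prior step.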

Compound 4, half-maximal effective concentration: 507 nM
Compound 4: the middle estimate sits 1.1-fold (0.05 log units) below what was measured; the measured number falls inside the stated range.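

In this assay, putting 4-methylphenyl in place of 3-methylphenyl on the core of compound 3 gives a 2.1-fold lower number from compound 3 to compound 4 (0.32 log units; beyond the scatter). Set beside the same change on the core of compound 2, the step carries over from one core to the other with no difference that can be told apart: the same change on two cores in this assay, a 2.4-fold lower number (0.39 log units; beyond the scatter) from compound 2 to compound 1 and a 2.1-fold lower number (0.32 log units; beyond the scatter) from compound 3 to compound 4, 1.2-fold (0.07 log units) apart, within the scatter of two such steps. Among the compounds shown here, this is agreement between only two pairs of compounds, so it shows that the change transferred across these two cores in this assay, but it does not show that it would transfer to a third core, and it does not explain why the two steps match.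

The compounds shown leave open whether the same step would appear with a group other than methyl on the phenyl ring, such as chloro or methoxy. They also leave open whether it would survive replacing the carboxylic acid with a tetrazole or the propynyl chain with a cyclopropyl group.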